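The source may hold more compounds than are shown below. What is called first, only, known or untested is meant among the compounds shown, and "the series" means these compounds.

Measured so far in a functional assay on KB cells (Homo sapiens) for cytotoxicity; a higher number here means a weaker inhibitor, a lower number a stronger inhibitor:
Compound 1, `NC(=S)c1cn(COCc2ccccc2)c2ncnc(N)c12`, gives > 100000 nM, which is a limit of the assay rather than a number.
Compound 2, `Cc1ccc(Cn2cc(C#N)c3c(N)ncnc32)cc1`, gives > 100000 nM, again a limit.
Compound 3, `NC(=S)c1cn(COC(CO)CO)c2ncnc(N)c12`, gives > 100000 nM, also a limit.

Compound 3 therefore stands at the same limit as the other two; (the limit of > 100000 nM in this assay, at which 3 of the 3 values shown sit). Going by the values given here, the one measured step that touches the group in question is a step that the two limits leave unreadable from compound 1 to compound 3, and it cannot be read because both ends are limits. Compound 4, `NC(=S)c1cn(Cc2ccccc2)c2ncnc(N)c12`, differs from compound 3 by phenyl in place of 2-hydroxy-1-(hydroxymethyl)ethoxy on a saturated chain carbon bound to an aromatic nitrogen. With no readable step to lean on, no change beyond the scatter can be predicted in either direction. Compound 4 is expected to give 100000 nM (range 30000 nM to 300000 nM), most likely again as a limit, so the step of a number no higher from compound 3 to compound 4 (the limit leaves the size open) is estimated to be nil.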

Compound 4, half-maximal inhibitory concentration: 32000 nM
For compound 4 the middle estimate is 3.1-fold (0.49 log units) above the measured one, within the range that was stated.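

In this assay, the saturated chain carbon bound to an aromatic nitrogen proves sensitive to change: phenyl in place of 2-hydroxy-1-(hydroxymethyl)ethoxy gives an at least 3.1-fold lower number from compound 3 to compound 4 (0.49 log units; beyond the scatter). Going by these compounds alone, the earlier step cannot be read, so this is the first sign that the group here matters for cytotoxicity. Only compound 4 has left the limit, where the others remain: the limit of > 100000 nM in this assay, at which 3 of the 4 values shown sit.

The compounds shown leave open whether the change comes from gaining the phenyl or losing the 2-hydroxy-1-(hydroxymethyl)ethoxy group. They also leave open how an amine, a carboxylic acid or a longer chain at this place would compare.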